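Swapping a Phenol for a Tosylate on the Shared Core

The source may hold more compounds than are shown below. What is called first, only, known or untested is meant among the compounds shown, and "the series" means these compounds.

Of the compounds shown here, three built on the same core have been tested in a functional assay on HL-60 cells (Homo sapiens) for cytotoxicity, read by MTT assay, with a stated time of 4 days; a higher number here means a weaker inhibitor, a lower number a stronger inhibitor. Compound 1 `C=C1C(=O)[C@]23C[C@@]1(O)CC[C@H]2c1ccc(OS(=O)(=O)c2ccc(C)cc2)c(C)c1[C@@H]3Cn1cc(-c2ccc(Br)cc2)nn1` gives 1020 nM, compound 2 `C=C1C(=O)[C@]23C[C@@]1(O)CC[C@H]2c1ccc(OS(=O)(=O)c2ccc(C)cc2)c(C)c1[C@@H]3Cn1cc(-c2ccc(F)cc2)nn1` gives 1290 nM, and compound 3 `C=C1C(=O)[C@]23C[C@@]1(O)CC[C@H]2c1ccc(O)c(C)c1[C@@H]3Cn1cc(-c2ccc(OC)cc2)nn1` gives 1150 nM. The number for compound 3 lies within the usual scatter of both others; compound 2 is nearest to it and compound 1 furthest, and neither gap counts as a real difference. Among the measured compounds shown here, the one step measured so far, a 1.3-fold higher number from compound 1 to compound 2 (0.10 log units; within the scatter), is also within the scatter.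

Compound 4 `C=C1C(=O)[C@]23C[C@@]1(O)CC[C@H]2c1ccc(OS(=O)(=O)c2ccc(C)cc2)c(C)c1[C@@H]3Cn1cc(-c2ccc(OC)cc2)nn1` differs from compound 3 in one place: (4-methylphenyl)sulfonyl in place of hydrogen on an oxygen on an aromatic ring. For the measured compounds named here, no measured pair shows this exact change on its own. Compounds 1 and 2 already carry the entering group, and their numbers sit close to that of compound 3, though they also differ from it elsewhere in the structure. The step from compound 1 to compound 2 touches a different part of the molecule and bears on this change only as a sign that the numbers in this assay have moved little across the set. The expected step in this assay is therefore no change at the digits printed from compound 3 to compound 4 (within the scatter), which is no change beyond the scatter. Compound 4 is expected to give 1150 nM, with a range from 500 nM to 2600 nM.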

Compound 4, half-maximal inhibitory concentration: 1020 nM
The estimate for compound 4 lay 1.1-fold (0.05 log units) above the measured number; low and high end bracket the measured number.
By their numbers in this assay, from the lowest: compounds 1, 4, 3 and 2 (each within the scatter of the next).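

In this assay, among the compounds shown here, (4-methylphenyl)sulfonyl in place of hydrogen on an oxygen on an aromatic ring gives a 1.1-fold lower number from compound 3 to compound 4 (0.05 log units; within the scatter), the first direct reading of this change, and it shows that the hydroxy and ((4-methylphenyl)sulfonyl)oxy forms of this pair cannot be told apart in this assay. With that sulfonyl group kept in place, the group on the other aromatic ring also makes no real difference: methoxy in place of fluoro gives a 1.3-fold lower number from compound 2 to compound 4 (0.10 log units; within the scatter), and methoxy in place of bromo gives no change at the digits printed from compound 1 to compound 4 (within the scatter). No measurement on hand explains why these numbers stay so close.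

Only hydrogen and (4-methylphenyl)sulfonyl are shown on this oxygen, so it remains open whether a methyl, an acetyl or a short chain ending in an amine there would move the number beyond the scatter. From the compounds shown here alone, it also remains open whether a carboxylic acid or an amine in place of the methoxy would do so, and whether the bromo and fluoro compounds would stay as close with a free hydroxy.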